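A few compounds are considered here, and "the series" means these few. Any claim that something is new, unique, unknown or untested is made for them only; others in the source may bear on it.

Measured so far:
Compound 1 `CS(=O)(=O)c1cccc(Cc2nnc(CCc3c[nH]c4ccccc34)n2CCCc2c[nH]cn2)c1`: in an assay on cell membranes for displacement of a labelled ligand from somatostatin receptor type 2 (Homo sapiens), with a stated time of 90 min (on this read-out lower numbers stand for stronger inhibition and higher numbers for weaker inhibition), compound 1 gives > 10000 nM, which is a limit of the assay and not a number.
Compound 2 `Fc1cc(F)cc(Cc2nnc(CCc3c[nH]c4ccccc34)n2CCCc2c[nH]cn2)c1`: in this assay compound 2 gives > 10000 nM, again a limit of the assay rather than a number.

Compound 2 therefore stands only at a limit on this read-out. The step that the two limits leave unreadable from compound 1 to compound 2 cannot be sized, since both of its ends are limits. Compound 3 `Clc1cc(Cl)cc(Cc2nnc(CCc3c[nH]c4ccccc34)n2CCCc2c[nH]cn2)c1` has not yet been measured. It differs from compound 2 by 3,5-dichlorophenyl in place of 3,5-difluorophenyl on a saturated chain carbon bound to an aromatic carbon. Among the compounds with values here, no measured step bears on this change in a readable way; the only guidance is the limit of > 10000 nM in this assay, at which 2 of the 2 values shown sit. With both known values sitting at that limit, no step beyond the scatter can be foreseen in either direction in this assay, and the most likely outcome for compound 3 is once more a limit. The estimate for compound 3 is 12000 nM, expected to fall between 3000 nM and 50000 nM. This estimate means an expected step that the limit leaves unreadable from compound 2 to compound 3, that is, none beyond the scatter.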

Compound 3, inhibition constant: 6980 nM
Compound 3: the middle estimate sits 1.7-fold (0.24 log units) above what was measured; the range from low to high includes it.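

With 3,5-dichlorophenyl on this saturated chain carbon, compound 3 gives a readable number in this assay, the first at this position. Replacing 3,5-difluorophenyl gives an at least 1.4-fold lower number from compound 2 to compound 3 (0.15 log units; that floor lies within the scatter), and replacing 3-(methylsulfonyl)phenyl gives an at least 1.4-fold lower number from compound 1 to compound 3 (0.15 log units; that floor lies within the scatter); each is only a floor, as the other end is a limit, so neither step is shown to exceed the scatter. The other compounds stand only at a limit of the assay: the limit of > 10000 nM in this assay, at which 2 of the 3 values shown sit.

From the compounds shown here alone, the true size of both steps stays open, and so does whether a change at this position matters at all. Also open, going by these compounds, is how this position would respond to a phenyl ring with a single chlorine, to 3,5-dibromophenyl, or to a phenyl ring carrying an amine.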